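Amide chain variation on the shared core

A few compounds are considered here, and "the series" means these few. Any claim that something is new, unique, unknown or untested is made for them only; others in the source may bear on it.

Two compounds of this series carry numbers in an ADME assay on microsomes from liver (Homo sapiens) for metabolic stability; on this read-out lower numbers stand for a shorter-lived compound and higher numbers for a longer-lived compound. Compound 1 `Cn1cc(-c2ccc(F)cc2)c(=O)c2c(Nc3ccc(Oc4ccnc(NC(=O)C5CC5)c4)c(F)c3)nccc21` gives 14.7 h in this assay. Compound 2 `CCC(=O)Nc1cc(Oc2ccc(Nc3nccc4[nH]cc(-c5ccc(F)cc5)c(=O)c34)cc2F)ccn1` gives 2.72 h in this assay, the lowest of the two numbers; compound 1 holds the nearest number, which is higher, and that gap lies beyond the scatter. Among the measured compounds shown here, no step is computed between compound 1 and compound 2, as they differ in more than one place, so only the two values themselves can be compared.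

Compound 3 `CC(O)C(=O)Nc1cc(Oc2ccc(Nc3nccc4[nH]cc(-c5ccc(F)cc5)c(=O)c34)cc2F)ccn1` has not been measured in this assay. It differs from compound 2 in one place: hydroxy in place of hydrogen on a saturated chain carbon bound to a carbonyl carbon and a saturated chain carbon. For the measured compounds named here, no measured pair shows this change, so its size is not known from the series. The expected step of a 1.3-fold higher number from compound 2 to compound 3 (0.11 log units; within the scatter) is small, likely within the scatter, with no direction favoured. The estimate for compound 3 in this assay is 3.5 h, with a range from 1.4 h to 9 h.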

Compound 3, half-life: 4.15 h
The estimate for compound 3 lay 1.2-fold (0.07 log units) below the measured number; measured number inside the range.
By their numbers in this assay, from the lowest: compounds 2 and 3 (each within the scatter of the next); then compound 1.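

Read in this assay, the change from ethyl to 1-hydroxyethyl on the amide chain gives a 1.5-fold higher number from compound 2 to compound 3 (0.18 log units; within the scatter) as the first one-place step in this series. At this saturated chain carbon, bound to a carbonyl carbon and a saturated chain carbon, hydroxy in place of hydrogen therefore leaves no difference that can be told from the scatter. Compound 1 differs from compound 2 and compound 3 in more than one place, so its number says nothing about this change.

From the compounds shown here alone, whether an amine, a carboxylic acid or a longer chain at this carbon would move the number beyond the scatter of compound 2 stays open. Also open, going by these compounds, is whether hydroxy on the amide chain of compound 1 would give a step of similar size. No measurement at hand bears on the reason for this result.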